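A few compounds are considered here, and "the series" means these few. Any claim that something is new, unique, unknown or untested is made for them only; others in the source may bear on it.

In a physicochemical assay for solubility, at pH 7 (on this read-out lower numbers stand for lower solubility and higher numbers for higher solubility), compound 3 `CC(C)(C)C(=O)N1Cc2c(NC(=O)c3ccc(F)cc3)n[nH]c2C1(C)C` gives 235000 nM and compound 2 `CC(C)(C)C(=O)N1Cc2c(NC(=O)c3cccnc3)n[nH]c2C1(C)C` gives 207000 nM, two values within the scatter of each other. Compound 1 `CC(C)(C)C(=O)N1Cc2c(NC(=O)C3CCNCC3)n[nH]c2C1(C)C` reports > 225000 nM, which is a limit of the assay and not a number, as the limit of > 225000 nM in this assay, at which 1 of the 3 values shown sits, records. Compound 4 `CN(C)CC(=O)Nc1n[nH]c2c1CN(C(=O)C(C)(C)C)C2(C)C` differs from compound 3 by (dimethylamino)methyl in place of 4-fluorophenyl on a carbonyl carbon, with (dimethylamino)methyl in place of 4-fluorophenyl on a carbonyl carbon. Two measured changes at this carbonyl carbon can be sized: a 1.1-fold higher number from compound 2 to compound 3 (0.06 log units; within the scatter) and an at least 1.0-fold lower number from compound 1 to compound 2 (0.03 log units; that floor lies within the scatter). A third, a step that the limit leaves unreadable from compound 1 to compound 3, cannot. Neither sized change shows a shift beyond the scatter, so none is expected here, and the expected step is a 1.0-fold lower number from compound 3 to compound 4 (0.02 log units; within the scatter). For compound 4 the estimated value is 225000 nM, with an expected range of 120000 nM to 400000 nM.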

Compound 4, solubility: > 225000 nM
Compound 4: no number, only a limit (the forecaster's own chance of this, stated with the estimate: 50%); the middle value sits exactly at the limit.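

In this assay compound 4 gives > 225000 nM, a limit and not a number. Among the compounds shown here, the one readable step, an at least 1.0-fold higher number from compound 2 to compound 4 (0.03 log units; that floor lies within the scatter), is only a floor, and the steps involving compound 3 and compound 1 cannot be read. With (dimethylamino)methyl, a group with no ring, on this carbonyl carbon, no readable step lies beyond the scatter, and records at the limit now number two: the limit of > 225000 nM in this assay, at which 2 of the 4 values shown sit.

As far as these compounds go, whether a carboxylic acid or a longer hydrocarbon chain on this carbonyl carbon would shift the read-out beyond the scatter stays open. From the compounds shown here alone, the actual values of compound 1 and compound 4 also stay open.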